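This account rests on a few compounds, and the source may have more. Where it says the series, first, only, none or still open, it means among the compounds named here.

Compound 1 `Cn1c(Cc2nn(C)c(=O)c3ccccc23)nnc1SCCCCCCCC(=O)Nc1ccc(Br)cc1Br`: 1500 nM
Compound 2 `Cn1c(Cc2nn(C)c(=O)c3ccccc23)nnc1SCCCCCCCCCCC(=O)Nc1ccccc1Cl`: 15000 nM
Compound 3 `CCCCCCCCCCSc1nnc(Cc2nn(C)c(=O)c3ccccc23)n1C`: 7600 nM

In an assay on isolated protein (Mus musculus) for inhibition of IL15-IL15 receptor (Homo sapiens), read by resazurin assay, with stated times of 30 min and 2.5 days (on this read-out lower numbers stand for stronger inhibition and higher numbers for weaker inhibition), compound 1 stands lowest of the three. The nearest measured compound is compound 3, reached by a 5.1-fold higher number from compound 1 to compound 3 (0.70 log units; beyond the scatter); compound 2 stands furthest, at 15000 nM. Compound 4 `CCCOc1ccc(NC(=O)CCCCCCCSc2nnc(Cc3nn(C)c(=O)c4ccccc34)n2C)cc1` has not yet been measured. It differs from compound 1 in one place: 4-propoxyphenyl in place of 2,4-dibromophenyl on an amide-type nitrogen. For the measured compounds named here, two steps bear on the amide end of the chain. Removing the whole (2,4-dibromophenyl)carbamoyl group gave a 5.1-fold higher number from compound 1 to compound 3 (0.70 log units; beyond the scatter), a modest loss, while a 2.0-fold lower number from compound 2 to compound 3 (0.30 log units; within the scatter) was within the scatter. Going by the values given here, no measured pair shows one aryl amide against another, so the swap to 4-propoxyphenyl is expected to give at most a small rise, a 2.0-fold higher number from compound 1 to compound 4 (0.30 log units; within the scatter). Compound 4 is therefore estimated at 3000 nM, between 1000 nM and 9000 nM.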

Compound 4, half-maximal inhibitory concentration: 1600 nM
The estimate for compound 4 lay 1.9-fold (0.27 log units) above the measured number; low and high end bracket the measured number.
By their numbers in this assay, from the lowest: compounds 1 and 4 (each within the scatter of the next); then compounds 3 and 2 (each within the scatter of the next).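

At this position on the amide-type nitrogen, 2,4-dibromophenyl and 4-propoxyphenyl cannot be told apart, with a 1.1-fold higher number from compound 1 to compound 4 (0.03 log units; within the scatter). This is the only pair shown that sets one aryl amide against another on the same chain, and it shows that bromine on the ring is not required for a number of this size. No measurement on hand explains this match.

The compounds shown leave open whether an amine or a carboxylic acid on this ring would give a similar number. They also leave open how a longer chain would behave with 4-propoxyphenyl.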